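This account rests on a few compounds, and the source may have more. Where it says the series, first, only, none or still open, it means among the compounds named here.

Working notes on a small series assessed in a functional assay on VCaP cells (Homo sapiens) for antiproliferative activity, read by propidium iodide staining, with a stated time of 96 h; a higher number here means a weaker inhibitor, a lower number a stronger inhibitor.

Compound 1 `CC(O)(COc1ccc(S(F)(F)(F)(F)F)cc1)C(=O)Nc1ccc(C#N)c(C(F)(F)F)c1` gives 30100 nM in this assay. Compound 2 `CC(O)(COc1ccc(S(F)(F)(F)(F)F)cc1)C(=O)Nc1ccc([N+](=O)[O-])c(C(F)(F)F)c1` differs from compound 1 by nitro in place of cyano on an aromatic carbon. In this assay compound 2 gives 100000 nM, so that the step of a 3.3-fold higher number from compound 1 to compound 2 (0.52 log units; beyond the scatter) weakens the inhibition by a modest but real margin.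

Compound 3 `CC1(C)C(=O)N(c2ccc(C#N)cc2C(F)(F)F)C(=S)N1c1ccc(S(F)(F)(F)(F)F)cc1` carries a different core; the difference between the core of compound 3 and the core of compound 1 is not broken down here. In this assay compound 3 gives 100000 nM, level with compound 2 at the digits recorded and together with it the highest number of the three measured; against compound 1 it stands a clear step higher.

Compound 4 `CC1(C)C(=O)N(c2ccc([N+](=O)[O-])cc2C(F)(F)F)C(=S)N1c1ccc(S(F)(F)(F)(F)F)cc1` is not yet measured. It differs from compound 3 by nitro in place of cyano on an aromatic carbon. Going by the values given here, this is the same kind of change as the one from compound 1 to compound 2, but not the same: in compound 1 the replaced cyano sits ortho to the trifluoromethyl group, whereas in compound 3 it sits meta to it, while in both cases it is para to a large group.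

Among the compounds with values here, the only measured precedent for this change is the step of a 3.3-fold higher number from compound 1 to compound 2 (0.52 log units; beyond the scatter). Carried onto compound 3, which already gives 100000 nM, an expected step of no change at the digits printed from compound 3 to compound 4 (within the scatter) would take compound 4 to or beyond the top of the measured range. For compound 4 the estimate in this assay is therefore 100000 nM, within 50000 nM to 300000 nM, with a substantial chance that only a limit rather than a number is returned.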

Compound 4, half-maximal inhibitory concentration: 100000 nM
Compound 4: middle estimate and measured number agree at the digits printed; the range from low to high includes it.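

In this assay, nitro in place of cyano on an aromatic carbon gives no change at the digits printed from compound 3 to compound 4 (within the scatter), and this step does not match the one seen on the core of compound 1: the same change on two cores in this assay, a 3.3-fold higher number (0.52 log units; beyond the scatter) from compound 1 to compound 2 and no change at the digits printed (within the scatter) from compound 3 to compound 4, 3.3-fold (0.52 log units) apart, beyond the scatter of two such steps. The size of this change therefore does not carry over unaltered from one core to the other, and the step measured on one core is a poor guide to the step on the other in this series. This does not show why the two steps part, since the two pairs differ both in the core and in where the replaced group sits relative to the trifluoromethyl group, and two pairs cannot separate these; nor does it show that nitro and cyano are interchangeable on the core of compound 3 in general, as compound 3 already gives 100000 nM, a high number with the step read from that one starting point only.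

Open, on these data alone, is how an amine or a carboxylic acid in place of the cyano would read on each of the two cores. Also open, as far as these compounds go, is whether a chlorine atom at that carbon would give steps that agree between the cores or part as these two do.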